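This account rests on a few compounds, and the source may have more. Where it says the series, first, only, none or still open, it means among the compounds named here.

Measured in a functional assay on I10 cells (Mus musculus) for inhibition, read by MTT assay, with a stated time of 72 h; on this read-out lower numbers stand for stronger inhibition and higher numbers for weaker inhibition:
- compound 1 `C=CCc1ccc(OCc2c(Cl)cccc2Cl)c(-c2ccc(OCc3c(Cl)cccc3Cl)c(CC=C)c2)c1` gives > 50000 nM (a limit of the assay, not a number)
- compound 2 `C=CCc1ccc(O)c(-c2ccc(OCc3ccc(Cl)c(Cl)c3)c(CC=C)c2)c1` gives 12300 nM
- compound 3 `C=CCc1ccc(O)c(-c2ccc(OCc3c(Cl)cccc3Cl)c(CC=C)c2)c1` gives 16600 nM

Compound 1 has no exact number, since it sits at the limit of > 50000 nM in this assay, at which 1 of the 3 values shown sits, and that is only a limit.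

Compound 4 `C=CCc1ccc(OCc2c(Cl)cccc2Cl)c(-c2ccc(O)c(CC=C)c2)c1` differs from compound 1 by a single change: hydrogen in place of 2,6-dichlorobenzyl on an oxygen on an aromatic ring so hydroxy stands where (2,6-dichlorobenzyl)oxy stood. The closest guide is compound 3, which carries the same replacement at the other such oxygen of compound 1. That step is an at least 3.0-fold lower number from compound 1 to compound 3 (0.47 log units; beyond the scatter) and it gives only a lower bound on the size. A second step, a 1.3-fold higher number from compound 2 to compound 3 (0.13 log units; within the scatter), shows that the two dichlorobenzyl patterns on compounds with one free hydroxy stay close together. Going by the values given here, no measured compound shows whether the two oxygens behave alike, so the guide is imperfect. A step of similar size and direction therefore seems the fair expectation. Expected in this assay is an at least 3.3-fold lower number from compound 1 to compound 4 (0.52 log units; beyond the scatter), toward a lower number. Compound 4 is estimated at 15000 nM, with an expected range from 6000 nM to 40000 nM.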

Compound 4, half-maximal inhibitory concentration: 17200 nM
Beside the measured number, compound 4's estimate is 1.1-fold (0.06 log units) below it, within the range that was stated.
By their numbers in this assay, from the lowest: compounds 2, 3 and 4 (each within the scatter of the next). At a limit, above all of these: compound 1.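

In this assay, putting hydrogen in place of 2,6-dichlorobenzyl on this oxygen gives an at least 2.9-fold lower number from compound 1 to compound 4 (0.46 log units; beyond the scatter). The same swap had been seen only at the other oxygen of compound 1, as an at least 3.0-fold lower number from compound 1 to compound 3 (0.47 log units; beyond the scatter), so a lower number now goes with this change at either oxygen. Compound 1 stands at a limit, so each step gives only a minimum size, and the true sizes cannot be compared: the limit of > 50000 nM in this assay, at which 1 of the 4 values shown sits.

The compounds shown leave open whether the whole 2,6-dichlorobenzyl group must leave this oxygen, or whether a small methyl group or a short chain ending in an amine would read like hydrogen. They also leave open how the core would read with hydrogen on both oxygens.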